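The source may hold more compounds than are shown below. What is called first, only, known or untested is meant among the compounds shown, and "the series" means these compounds.

Measured compounds: compound 1 `O=C([C@@H]1CCCN(S(=O)(=O)c2ccc(S(=O)(=O)N3CC[C@@H](O)C3)cc2)C1)N1CCC(F)(F)CC1`, 330 nM; compound 2 `CCN(CC)S(=O)(=O)c1ccc(S(=O)(=O)N2CCC[C@@H](C(=O)NC3COC3)C2)cc1`, 13800 nM; compound 3 `CCN(CC)S(=O)(=O)c1ccc(S(=O)(=O)N2CCC[C@@H](C(=O)N[C@H]3CC[C@H](OC)CC3)C2)cc1`, 2000 nM.

In a functional assay on BXPC-3 cells (Homo sapiens) for inhibition, read by MTT assay, with a stated time of 7 days (on this read-out lower numbers stand for stronger inhibition and higher numbers for weaker inhibition), compound 1 gives the lowest of the three numbers, with compound 3 higher and compound 2 higher still. Compound 4 `O=C([C@@H]1CCCN(S(=O)(=O)c2ccc(S(=O)(=O)N3CC[C@H](O)C3)cc2)C1)N1CCC(F)(F)CC1` differs from compound 1 in one respect: the two compounds have the same atoms and bonds and differ only in configuration as drawn: 1 of 2 stereo elements differ; a stereocentre at a saturated ring carbon is drawn R in compound 1 and S in compound 4. Within the data shown here, the only measured step, a 6.9-fold lower number from compound 2 to compound 3 (0.84 log units; beyond the scatter), concerns the group on an amide-type nitrogen and does not bear on a change of configuration; no measured pair differs in configuration alone, so no direction can be anchored. Compound 4 is expected to give 450 nM, with a range of 150 nM to 1500 nM. Among the measured compounds shown here, the step expected is a 1.4-fold higher number from compound 1 to compound 4 (0.13 log units; within the scatter), none beyond the scatter, the range being widened because this kind of change has no precedent among the measured compounds.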

Compound 4, half-maximal inhibitory concentration: 580 nM
Compound 4: the middle estimate sits 1.3-fold (0.11 log units) below what was measured; the measured number falls inside the stated range.
By their numbers in this assay, from the lowest: compounds 1 and 4 (each within the scatter of the next); then compound 3; then compound 2.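

Changing the stereocentre at a saturated ring carbon gives a 1.8-fold higher number from compound 1 to compound 4 (0.24 log units; within the scatter) in this assay. Among these compounds, at this position, then, the two configurations as drawn cannot be told apart in this assay, something the earlier compounds, with no pair of this kind, could not show. The reading applies to this stereocentre alone and rests on one fact: the fact that compounds 1 and 4 differ only in the configuration as drawn.

Still open, going by these compounds, is the effect of inverting the second stereocentre of the core of compound 1. Also open, on these data alone, is how an amine or a carboxylic acid in place of the hydroxyl at this ring carbon would read out.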